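The source may hold more compounds than are shown below. What is called first, only, known or untested is meant among the compounds shown, and "the series" means these compounds.

Of the compounds shown here, two from this series have been tested in a functional assay on HCT-116 cells (Homo sapiens) for antiproliferative activity, read by CCK-8 assay, with a stated time of 72 h, tested at 2 uM; a lower number here means a weaker effect, a higher number a stronger effect of the compound at the concentration tested. The first is compound 1, `CN1CCN(c2nc(Cl)nc3c2ncn3Cc2ccc(C(=O)Nc3ccccc3N)cc2)CC1`, and in this assay compound 1 gives 71.6%. The second is compound 2, `Nc1ccccc1NC(=O)c1ccc(Cn2cnc3c(Nc4ccc(-c5ccccn5)cc4)nc(Cl)nc32)cc1`, and in this assay compound 2 gives 69.5%. These two numbers lie within the usual scatter of one another, so the data do not separate compound 2 from compound 1; compound 2 simply stands alongside compound 1 at a similar level of inhibition.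

The next compound is compound 3, `Nc1ccccc1NC(=O)c1ccc(Cn2cnc3c(Nc4cccc(OC(F)(F)F)c4)nc(Cl)nc32)cc1`. It differs from compound 2 in one place, described as follows: 3-(trifluoromethoxy)phenyl in place of 4-(pyridin-2-yl)phenyl on a nitrogen on an aromatic ring. No comparable single change has been measured within this set, so there is no shown step to lean on. Going by the values given here, with both measured numbers sitting close together, the expectation is that the change from compound 2 to compound 3 brings no step in this assay beyond the scatter, with a wide range to allow for the unknown. On that basis the value expected for compound 3 is 65%, somewhere between 45% and 82%, which corresponds to an expected step of a number 4.5 percentage points lower from compound 2 to compound 3 (within the scatter).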

Compound 3, a percentage reported as inhibition, at one concentration (the size of the read-out at that concentration, not a potency): 1.6%
For compound 3 the middle estimate is 63.4 percentage points above the measured one, outside the stated range (below it).
By their numbers in this assay, from the lowest: compound 3; then compounds 2 and 1 (each within the scatter of the next).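

In this assay, putting 3-(trifluoromethoxy)phenyl in place of 4-(pyridin-2-yl)phenyl on the nitrogen gives a number 67.9 percentage points lower from compound 2 to compound 3 (beyond the scatter), so a single change at this position can remove almost all of the inhibition seen at the concentration tested. Putting (3-(trifluoromethoxy)phenyl)amino in place of 4-methylpiperazin-1-yl on the aromatic carbon gives a number 70 percentage points lower from compound 1 to compound 3 (beyond the scatter), and this shows that the similar numbers of compound 1 and compound 2 did not mean that this position accepts any group. Nothing available here accounts for this loss of inhibition.

The compounds shown leave open whether the loss belongs to the trifluoromethoxy group itself or to the whole 3-(trifluoromethoxy)phenyl group, as no other group on a phenyl ring at this nitrogen appears among them. An unsubstituted phenyl on the same nitrogen would help to separate these two readings, and a morpholine on the same aromatic carbon would show whether a second ring of the 4-methylpiperazin-1-yl kind also holds the inhibition.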